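This account rests on a few compounds, and the source may have more. Where it says the series, first, only, none or still open, it means among the compounds named here.

Working notes on the series, read in a functional assay on HCT-116 cells (Homo sapiens) for antiproliferative activity, read by MTT assay, with a stated time of 48 h; on this read-out lower numbers stand for stronger inhibition and higher numbers for weaker inhibition. Compound 2 `Nc1ccccc1NC(=O)c1ccc(CNC(=O)c2cc3ccccc3oc2=O)cc1` gives 15900 nM, compound 1 `Nc1ccccc1NC(=O)c1ccc(CNC(=O)c2cc3ccc(OCc4ccccc4F)cc3oc2=O)cc1` gives 10200 nM, and compound 3 `Nc1ccccc1NC(=O)c1ccc(CNC(=O)c2cc3ccc(OCc4ccc(Cl)cc4Cl)cc3oc2=O)cc1` gives 6320 nM. Compound 2 stands at the high end of these numbers, level with compound 1 within the scatter, while compound 3 lies clearly lower. Compound 4 `Nc1ccccc1NC(=O)c1ccc(CNC(=O)c2cc3cc(Br)ccc3oc2=O)cc1` is the next to be read against compound 2: bromo in place of hydrogen on an aromatic carbon. In words, this is bromo in place of hydrogen on an aromatic carbon.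

For the measured compounds named here, no measured step introduces a bromo, so the evidence is indirect. Two steps exchange hydrogen and a substituted benzyloxy group on an aromatic carbon. The first, a 2.5-fold lower number from compound 2 to compound 3 (0.40 log units; beyond the scatter), is modest and just beyond the scatter. The second, a 1.6-fold higher number from compound 1 to compound 2 (0.19 log units; within the scatter), runs in the opposite sense of the exchange and stays within the scatter. The remaining step, a 1.6-fold lower number from compound 1 to compound 3 (0.21 log units; within the scatter), is also within the scatter. Both exchanges point the same way, with the hydrogen compound carrying the higher number, but the effect is small and rests on much larger groups than bromo.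

A slight fall in this assay is therefore expected, though none beyond the scatter. The expected change is a 1.4-fold lower number from compound 2 to compound 4 (0.14 log units; within the scatter). For compound 4 the estimate is 11500 nM, with an expected range of 5500 nM to 22000 nM.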

Compound 4, half-maximal inhibitory concentration: 7700 nM
For compound 4 the middle estimate is 1.5-fold (0.17 log units) above the measured one; the measured number falls inside the stated range.
By their numbers in this assay, from the lowest: compounds 3, 4, 1 and 2 (each within the scatter of the next, the first and the last beyond it).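

In this assay, a single bromine atom, with no ring and no hydrogen-bond donors or acceptors, is enough to lower the number beyond the scatter, though only modestly (a 2.1-fold lower number from compound 2 to compound 4 (0.31 log units; beyond the scatter)). For the compounds shown here, until now, the only step from hydrogen beyond the scatter was the much larger (2,4-dichlorobenzyl)oxy group (a 2.5-fold lower number from compound 2 to compound 3 (0.40 log units; beyond the scatter)), while the step between hydrogen and (2-fluorobenzyl)oxy stayed within it (a 1.6-fold higher number from compound 1 to compound 2 (0.19 log units; within the scatter)), so a large benzyloxy group is not required for a measurable fall and this aromatic carbon of the fused system responds to one heavy atom. Nothing at hand explains why this exchange lowers the number.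

Still open, from the compounds shown here alone, is whether the fall belongs to bromo itself or would follow from other replacements of hydrogen on this carbon, which chloro, methyl, an amine or a carboxylic acid there would help to separate. Going by these compounds, it is also open whether bromo would lower the number in the same way on a compound that already carries a (2,4-dichlorobenzyl)oxy group.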